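From butyl to isobutyl: compound 3 to compound 4

The compounds below may be only part of what the source reports. "The series", "measured", "known", "first", "only" and "open" are said of these compounds alone.

In a functional assay on MDA-MB-231 cells (Homo sapiens) for antiproliferative activity, read by MTT assay, with a stated time of 72 h (on this read-out lower numbers stand for stronger inhibition and higher numbers for weaker inhibition), compound 1 (`COc1cc(-c2nccn2C)cc(OC)c1OC`) gives > 100000 nM, a limit of the assay and not a number. Compound 2 (`CCCn1ccnc1-c1cc(OC)c(OC)c(OC)c1`) gives > 100000 nM, also a limit. For the measured compounds named here, compound 3 (`CCCCn1ccnc1-c1cc(OC)c(OC)c(OC)c1`) gives 70400 nM, the only true number of the three. Compound 4 (`COc1cc(-c2nccn2CC(C)C)cc(OC)c1OC`) has the same atoms as compound 3, joined differently, turning butyl to isobutyl: isopropyl in place of propyl on a saturated chain carbon bound to an aromatic nitrogen. The nearest measured steps are an at least 1.4-fold lower number from compound 1 to compound 3 (0.15 log units; that floor lies within the scatter) and an at least 1.4-fold lower number from compound 2 to compound 3 (0.15 log units; that floor lies within the scatter), and both floors lie within the scatter. Neither of them swaps a chain for its branched form, so no step beyond the scatter is expected. The estimated change is a 1.2-fold higher number from compound 3 to compound 4 (0.08 log units; within the scatter). For compound 4 the expected value is 85000 nM, with an estimated range of 45000 nM to 150000 nM.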

Compound 4, half-maximal inhibitory concentration: > 100000 nM
Compound 4: only a limit was reported; the forecaster's own chance of this, stated with the estimate: 45%; middle value at least 1.1-fold (0.07 log units) away from the limit.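

In this assay, turning butyl into isobutyl gives an at least 1.4-fold higher number from compound 3 to compound 4 (0.15 log units; that floor lies within the scatter), so branching at this position brings no measurable gain, although the limit on compound 4 hides the true size of the step. The steps linking compound 4 to compound 1 and compound 2 cannot be read, as both ends of each are limits. Straight-chain butyl in compound 3 thus remains the only true number at this position, and comparison is narrow: the limit of > 100000 nM in this assay, at which 3 of the 4 values shown sit.

From the compounds shown here alone, whether a longer chain such as hexyl would lower the number further stays open. So does the effect of an amine carried on the chain.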